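A few compounds are considered here, and "the series" means these few. Any claim that something is new, unique, unknown or untested is made for them only; others in the source may bear on it.

Measured compounds in a functional assay on OVCAR-3 cells (Homo sapiens) for inhibition; a lower number here means a stronger inhibitor, a higher number a weaker inhibitor:

compound 1 `CC(C)(C)NC(=O)N1CC1C#N` gives 186000 nM
compound 2 `N#CC1CN1C(=O)Nc1cccc2ccccc12` gives 5900 nM
compound 3 `N#CC1CN1C(=O)Nc1ccc(C(F)(F)F)cc1` gives 5900 nM

Compound 1 stands at the highest of the three numbers in this assay. Compound 2 and compound 3, both carrying an aromatic group on the urea nitrogen, lie well below it, and the gap from compound 1 to either of them is far beyond the scatter. Compound 2 and compound 3 themselves sit at the same number, so nothing separates them. Among the measured compounds shown here, compound 1 is the only member with an alkyl group on that nitrogen, so the series gives no measured step between two alkyl ureas.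

Compound 4 `CCNC(=O)N1CC1C#N` keeps the shared core of compound 1 and differs in one place: ethyl in place of tert-butyl on an amide-type nitrogen. For the measured compounds named here, no measured pair covers this kind of exchange. The two aromatic ureas show that this position matters, but they say nothing about one alkyl chain against another. The working expectation is a step in this assay of no clear direction and not beyond the scatter: a 1.1-fold higher number from compound 1 to compound 4 (0.03 log units; within the scatter).

On that basis compound 4 is estimated at 200000 nM, with a range from 60000 nM to 700000 nM.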

Compound 4, half-maximal inhibitory concentration: 14000 nM
Compound 4: the middle estimate sits 14-fold (1.15 log units) above what was measured; measured number outside the range, below it.
By their numbers in this assay, from the lowest: compounds 2 and 3 (each within the scatter of the next); then compound 4; then compound 1.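

In this assay, among the compounds shown here, ethyl in place of tert-butyl on an amide-type nitrogen gives a 13-fold lower number from compound 1 to compound 4 (1.12 log units; beyond the scatter) and so shows that this position responds to the choice of alkyl group itself, which the earlier compounds could not show with only one alkyl urea among them. The smaller group, with 2 heavy atoms against 4 carbon-bearing heavy atoms in tert-butyl, carries the lower number here, but this single step fixes a direction for this one pair only and sets no trend across alkyl groups. Nothing available explains the size of this step.

Still open, from the compounds shown here alone, is whether the number keeps falling with a methyl group or rises again with a longer chain such as n-butyl, and where an isopropyl group, branched like tert-butyl but smaller, would fall between the two measured alkyl ureas. Equally open, going by these compounds, is how this nitrogen would respond to an alkyl chain ending in an amine or a carboxylic acid, so the alkyl side of the series remains defined by two points.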